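Amide series: isopropyl for oxolanyl on the ring nitrogen

The source may hold more compounds than are shown below. What is called first, only, known or untested is meant among the compounds shown, and "the series" means these compounds.

Measured so far:
compound 1 `CC(C)N(C)c1ccc2cc(NC(=O)CCc3ccc(C(F)(F)F)cc3)cnc2n1` — 365 nM
compound 2 `CC(C)N(C)c1nc2ccc(NC(=O)CCc3ccc(C(F)(F)F)cc3)cc2s1` — > 750 nM
compound 3 `CN(c1nc2ccc(NC(=O)CCc3ccc(C(F)(F)F)cc3)cc2[nH]1)C1CCOC1` — 27 nM

In an assay on CHO-K1 cells for displacement of a labelled ligand from melanin-concentrating hormone receptor 1 (Homo sapiens), read by scintillation counting (on this read-out higher numbers stand for weaker inhibition and lower numbers for stronger inhibition), compound 3 gives 27 nM, the lowest of the two numbers shown, and compound 1 sits well beyond the scatter from it. Compound 2 is reported only as a limit of the assay, (the limit of > 750 nM in this assay, at which 1 of the 3 values shown sits). For the measured compounds named here, no pair of measured compounds differs in a single place, so no measured step is available.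

Compound 4 `CC(C)N(C)c1nc2ccc(NC(=O)CCc3ccc(C(F)(F)F)cc3)cc2[nH]1` is the next point: it carries isopropyl in place of oxolan-3-yl on a nitrogen on an aromatic ring, (isopropyl in place of oxolan-3-yl on a nitrogen on an aromatic ring), and is otherwise the same as compound 3. Compounds 1 and 2 carry the isopropyl(methyl)amino group on other cores, but their values are not a step to compound 3 and only show where those compounds lie.

Compound 4 is expected to show a modest loss, with a 3.0-fold higher number from compound 3 to compound 4 (0.47 log units; beyond the scatter) as the estimated step in this assay. Compound 4 is therefore estimated at 80 nM, within 25 nM to 300 nM.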

Compound 4, half-maximal inhibitory concentration: 5.9 nM
Compound 4: the middle estimate sits 14-fold (1.13 log units) above what was measured; the whole stated range lies above it.
By their numbers in this assay, from the lowest: compound 4; then compound 3; then compound 1. At a limit, above all of these: compound 2.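

In this assay replacing this group gives a 4.6-fold lower number from compound 3 to compound 4 (0.66 log units; beyond the scatter) and provides the first single-place change measured in the series. On a nitrogen on an aromatic ring, the oxolan-3-yl ring with its oxygen is therefore not required for a low number on this core, and the smaller open-chain isopropyl, which has no hydrogen-bond acceptor, gives the lower number of the pair. No measured property among the data shown bears on this step.

The compounds shown leave open how far this position tolerates other groups, such as cyclopropyl, tert-butyl or a longer alkyl chain. They also leave open whether the methyl on the same nitrogen can give way to hydrogen or ethyl, and whether oxolan-3-yl would shift the numbers on the cores of compound 1 and compound 2.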